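The source may hold more compounds than are shown below. What is called first, only, known or untested is meant among the compounds shown, and "the series" means these compounds.

Compound 1, `FC(F)(F)c1ccccc1Nc1nc2nonc2nc1Nc1ccccc1C(F)(F)F`, and compound 2, `CCc1ccc(Nc2nc3nonc3nc2Nc2ccc(CC)cc2)cc1`, are the two compounds of this set with numbers in hand. In an assay on mitochondria from L6 cells (Rattus norvegicus) for activation, with a stated time of 90 min (on this read-out higher numbers stand for an effect only at larger amounts of compound and lower numbers for an effect already at smaller amounts), compound 1 gives 1000 nM, and in the same read-out compound 2 gives 3900 nM. Compound 1 thus stands at the lower of the two numbers, and the gap to compound 2 lies beyond the usual scatter of repeated measurements, so the two compounds are told apart by this assay.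

Compound 3, `Fc1ccccc1Nc1nc2nonc2nc1Nc1ccccc1C(F)(F)F`, has not yet been measured. It differs from compound 1 in one place: fluoro in place of trifluoromethyl on an aromatic carbon. Going by the values given here, no pair of measured compounds here shows what this change does on its own, so the expectation rests only on the change itself and on the two numbers already known. The account expects a modest rise in the number, that is, a step from compound 1 to compound 3 of about a 2.5-fold higher number from compound 1 to compound 3 (0.40 log units; beyond the scatter), somewhat beyond the scatter but not large. Compound 3 is accordingly estimated at 2500 nM, with a range from 800 nM to 8000 nM.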

Compound 3, half-maximal effective concentration: 1400 nM
Compound 3: middle estimate off by 1.8-fold (0.25 log units), on the high side; the measured number falls inside the stated range.
By their numbers in this assay, from the lowest: compounds 1 and 3 (each within the scatter of the next); then compound 2.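

In this assay fluoro in place of trifluoromethyl on this aromatic carbon gives a 1.4-fold higher number from compound 1 to compound 3 (0.15 log units; within the scatter) and so the read-out does not tell the two compounds apart. Going by these compounds alone, this is the first comparison in the set that isolates a single place, and it shows that the 2-(trifluoromethyl)phenyl of compound 1 can become 2-fluorophenyl, with 4 heavy atoms leaving and 1 entering, without a change that this assay can resolve. No measurement on hand bears on why the number holds, and the result therefore stays a plain observation.

The compounds shown leave open whether a group of another kind on the same aromatic carbon, such as an amine, a carboxylic acid or a longer chain, would leave the number just as undisturbed, or whether the tolerance seen here extends only to fluoro and trifluoromethyl. They also leave open how the number would respond if the remaining 2-(trifluoromethyl)phenyl of compound 3 were changed to 2-fluorophenyl as well, so that no trifluoromethyl stayed on the molecule.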